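Chloroaryl carbamoyl-amino variants on a shared core: working notes

The compounds below may be only part of what the source reports. "The series", "measured", "known", "first", "only" and "open" are said of these compounds alone.

Measured compounds:
compound 1 `COc1cc(NC(C)CCCNC(=O)NNC(=O)Nc2cccc(Cl)c2)c2ncccc2c1` gives 32000 nM in a functional assay on NCI-H460 cells (Homo sapiens) for inhibition, read by MTT assay, with a stated time of 72 h; on this read-out lower numbers stand for stronger inhibition and higher numbers for weaker inhibition
compound 2 `COc1cc(NC(C)CCCNC(=O)Nc2cccc(Cl)c2)c2ncccc2c1` gives 37000 nM

Among the measured compounds shown here, compound 2 stands with compound 1 as its only neighbour, and a 1.2-fold higher number from compound 1 to compound 2 (0.06 log units; within the scatter) lies within the scatter, so the two cannot be separated. Compound 3 `COc1cc(NC(C)CCCNC(=O)NNC(=O)Nc2ccc(Cl)cc2)c2ncccc2c1` differs from compound 2 by ((4-chlorophenyl)carbamoyl)amino in place of 3-chlorophenyl on an amide-type nitrogen. For the measured compounds named here, the only step that bears on this is the one from compound 1 to compound 2; it covered the carbamoyl-amino link and stayed within the scatter, but it says nothing about 3-chlorophenyl against 4-chlorophenyl. Compound 3 is therefore expected to show no step beyond the scatter, a 1.1-fold lower number from compound 2 to compound 3 (0.05 log units; within the scatter). The estimate for compound 3 is 33000 nM, within 14000 nM to 75000 nM.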

Compound 3, half-maximal inhibitory concentration: 63000 nM
Beside the measured number, compound 3's estimate is 1.9-fold (0.28 log units) below it; measured number inside the range.
By their numbers in this assay, from the lowest: compounds 1, 2 and 3 (each within the scatter of the next).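

The para-style comparison is now direct: 4-chlorophenyl in place of 3-chlorophenyl on an amide-type nitrogen stays unresolved (a 2.0-fold higher number from compound 1 to compound 3 (0.29 log units; within the scatter)). Exchanging 3-chlorophenyl for ((4-chlorophenyl)carbamoyl)amino, which changes both the link and the chlorophenyl group, is also unresolved (a 1.7-fold higher number from compound 2 to compound 3 (0.23 log units; within the scatter)), so neither change separates these compounds in this assay. No supporting evidence bears on these results.

From the compounds shown here alone, whether an unsubstituted phenyl, a methoxyphenyl or a pyridyl group at this place would give a step beyond the scatter stays open. A longer chain between the shared core and the urea is equally untested here.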